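The source may report more compounds than this note shows. Statements on the series, on what has been measured and on what is new or still open speak of the compounds shown alone.

Three compounds built on the shared core have numbers in a functional assay on DU-145 cells (Homo sapiens) for inhibition, read by MTT assay, with a stated time of 48 h; on this read-out lower numbers stand for stronger inhibition of growth and higher numbers for weaker inhibition of growth. Compound 1 `C#CCN(C)Cc1cccc(NC(=O)CCCCCCCC(=O)NO)c1` gives 3780 nM. Compound 2 `C#CCN(C)Cc1cccc(NCc2ccc(/C=C/C(=O)NO)cc2)c1` gives 540 nM, and compound 3 `C#CCN(C)Cc1ccc(NCc2ccc(/C=C/C(=O)NO)cc2)cc1` gives 560 nM. Compound 2 has the lowest number of the three, with compound 3 sitting within the scatter of it and compound 1 lying beyond the scatter at a higher number. Compound 4 `C#CCN(C)Cc1cccc(NCc2ccc(C(=O)NO)cc2)c1` is not yet measured. From compound 2 it differs by one change: hydroxycarbamoyl in place of 2-(hydroxycarbamoyl)ethenyl on an aromatic carbon. Among the compounds with values here, no measured pair in the set shows a step of this kind, so the expectation rests on the change alone. A step toward weaker inhibition of growth is expected, larger than the scatter. The expected step is a 3.7-fold higher number from compound 2 to compound 4 (0.57 log units; beyond the scatter). Compound 4 is therefore estimated at 2000 nM, in the range 700 nM to 6000 nM.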

Compound 4, concentration for 50% growth inhibition: > 10000 nM
Compound 4 ended at the assay's limit (the forecaster's own chance of this, stated with the estimate: 5%); middle value at least 5.0-fold (0.69 log units) away from the limit.
By their numbers in this assay, from the lowest: compounds 2 and 3 (each within the scatter of the next); then compound 1. At a limit, above all of these: compound 4.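

In this assay compound 4 gives > 10000 nM, which is a limit of the assay and not a number. Within the data shown here, on this aromatic carbon, para to a large group, hydroxycarbamoyl in place of 2-(hydroxycarbamoyl)ethenyl gives an at least 18-fold higher number from compound 2 to compound 4 (1.26 log units; beyond the scatter), the first single-place step, and it shows that growth inhibition depends strongly on this side chain. The step has no upper bound: the limit of > 10000 nM in this assay, at which 1 of the 4 values shown sits.

Open, as far as these compounds go, is whether the double bond or the chain length matters, which a saturated 2-(hydroxycarbamoyl)ethyl group or a longer chain ending in hydroxycarbamoyl would separate.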